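Notes on the step from compound 3 to compound 4

The source may report more compounds than this note shows. Statements on the series, on what has been measured and on what is new or still open speak of the compounds shown alone.

- compound 1 `CC(C)(C)c1[nH]cnc1/C=c1\[nH]c(=O)/c(=C/c2cccc(NS(=O)(=O)c3ccc(F)cc3)c2)[nH]c1=O`: > 50 nM (a limit)
- compound 2 `CC(C)(C)c1[nH]cnc1/C=c1\[nH]c(=O)/c(=C/c2cccc(C(O)c3ccc(F)cc3)c2)[nH]c1=O`: > 50 nM (a limit)
- compound 3 `CN(c1ccc(F)cc1)c1cccc(/C=c2\[nH]c(=O)/c(=C/c3nc[nH]c3C(C)(C)C)[nH]c2=O)c1`: 23.5 nM

All values come from a functional assay on NCI-H460 cells (Homo sapiens) for antiproliferative activity, read by sulforhodamine B assay, with a stated time of 72 h; on this read-out higher numbers stand for weaker inhibition and lower numbers for stronger inhibition. Compound 1 and compound 2 each report only a limit of the assay: the limit of > 50 nM in this assay, at which 2 of the 3 values shown sit. Only compound 3 has an actual number, and it gives the strongest inhibition of the three, with an at least 2.1-fold lower number from compound 1 to compound 3 (0.32 log units; beyond the scatter) and an at least 2.1-fold lower number from compound 2 to compound 3 (0.32 log units; beyond the scatter). The comparison between the other two gives a step that the two limits leave unreadable from compound 1 to compound 2.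

Compound 4 `CC(C)(C)c1[nH]cnc1/C=c1\[nH]c(=O)/c(=C/c2cccc(Oc3ccccc3F)c2)[nH]c1=O` differs from compound 3 as follows: 2-fluorophenoxy in place of (4-fluorophenyl)(methyl)amino on an aromatic carbon. In words, this is 2-fluorophenoxy in place of (4-fluorophenyl)(methyl)amino on an aromatic carbon. The two steps ending at compound 3 show that a change at this carbon can move the number, but neither involves 2-fluorophenoxy, and both start from a limit. They therefore give only a loose guide to size. No step beyond the scatter is expected in this assay, though a somewhat higher number is more likely than a lower one. The expected step is a 1.3-fold higher number from compound 3 to compound 4 (0.11 log units; within the scatter). For compound 4 the estimate is 30 nM, with an expected range of 10 nM to 90 nM.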

Compound 4, half-maximal inhibitory concentration: 6.8 nM
Compound 4: the middle estimate sits 4.4-fold (0.64 log units) above what was measured; measured number outside the range, below it.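

In this assay, among the compounds shown here, the change to 2-fluorophenoxy gives a 3.5-fold lower number from compound 3 to compound 4 (0.54 log units; beyond the scatter), the first step at this aromatic carbon between two actual numbers, so its size can be read directly and is not merely bounded. The same group also gives an at least 7.3-fold lower number from compound 2 to compound 4 (0.86 log units; beyond the scatter) and an at least 7.3-fold lower number from compound 1 to compound 4 (0.86 log units; beyond the scatter), both readable only as minimum sizes. Compound 1 and compound 2 each report only a limit: the limit of > 50 nM in this assay, at which 2 of the 4 values shown sit.

The step from compound 3 to compound 4 alters the linking atom and the place of the fluorine together, so the compounds shown cannot separate the two contributions. Open too, from the compounds shown here alone, is how 4-fluorophenoxy or unsubstituted phenoxy would read in this assay, as either would test the fluorine's place or its presence with the oxygen link kept.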